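Replacing the trifluoromethoxyphenyl aniline with a methylphenyl group

A few compounds are considered here, and "the series" means these few. Any claim that something is new, unique, unknown or untested is made for them only; others in the source may bear on it.

Measured compounds:
compound 1 `COc1cc2ncnc(Nc3ccc(F)c(Cl)c3)c2cc1OCCCCC(=O)Nc1ccc(S(N)(=O)=O)cc1` 5020 nM
compound 2 `COc1cc2ncnc(Nc3cccc(Cl)c3F)c2cc1OCCCCC(=O)Nc1ccc(S(N)(=O)=O)cc1` 5560 nM
compound 3 `COc1cc2ncnc(Nc3ccc(OC(F)(F)F)cc3)c2cc1OCCCCC(=O)Nc1ccc(S(N)(=O)=O)cc1` 22500 nM

In a functional assay on A-431 cells (Homo sapiens) for antiproliferative activity, read by MTT assay, with a stated time of 72 h (on this read-out lower numbers stand for stronger inhibition and higher numbers for weaker inhibition), compound 3 gives the highest of the three numbers, set apart from the other two: a 4.5-fold higher number from compound 1 to compound 3 (0.65 log units; beyond the scatter) and a 4.0-fold higher number from compound 2 to compound 3 (0.61 log units; beyond the scatter), while a 1.1-fold higher number from compound 1 to compound 2 (0.04 log units; within the scatter). Compound 4 `COc1cc2ncnc(Nc3cccc(C)c3)c2cc1OCCCCC(=O)Nc1ccc(S(N)(=O)=O)cc1` differs from compound 3 by 3-methylphenyl in place of 4-(trifluoromethoxy)phenyl on a nitrogen on an aromatic ring. Going by the values given here, no measured step introduces a methylphenyl group, so only the two steps into compound 3 bear on it, and both show that a change of the aryl group on this nitrogen can shift the number by a modest amount. Compound 4 is therefore expected to sit below compound 3, with a 3.2-fold lower number from compound 3 to compound 4 (0.51 log units; beyond the scatter), a decrease of moderate size. The estimate for compound 4 is 7000 nM, with a range from 2500 nM to 20000 nM.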

Compound 4, half-maximal inhibitory concentration: 7460 nM
For compound 4 the middle estimate is 1.1-fold (0.03 log units) below the measured one, within the range that was stated.
By their numbers in this assay, from the lowest: compounds 1, 2 and 4 (each within the scatter of the next); then compound 3.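

In this assay, 3-methylphenyl on this nitrogen gives a clear shift away from the value of the 4-(trifluoromethoxy)phenyl compound (a 3.0-fold lower number from compound 3 to compound 4 (0.48 log units; beyond the scatter)). A ring bearing only a methyl group also matches the two chloro-fluoro rings (a 1.3-fold higher number from compound 2 to compound 4 (0.13 log units; within the scatter); a 1.5-fold higher number from compound 1 to compound 4 (0.17 log units; within the scatter)), so chlorine and fluorine on the ring are not required for numbers in this range, and compound 3 alone stands apart. Nothing given here accounts for this.

Still open, going by these compounds, is how a plain phenyl, a 3-methoxyphenyl or a 3-aminophenyl on this nitrogen would compare. Also open, on these data alone, is whether a 4-methylphenyl would follow compound 4 or compound 3.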